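Chloro to ethyl on the aromatic ring

The source may hold more compounds than are shown below. What is called first, only, known or untested is meant among the compounds shown, and "the series" means these compounds.

Values in a functional assay (Nicotiana tabacum); on this read-out higher numbers stand for weaker inhibition and lower numbers for stronger inhibition:
compound 1 `CSc1nc(Nc2ccc(F)cc2)c2cccnc2n1`: 2620 nM
compound 2 `CSc1nc(Nc2ccc(Cl)cc2)c2cccnc2n1`: 8510 nM

Of the two measured compounds, compound 2 stands higher at 8510 nM, which makes it the weaker inhibitor of the pair. The next change leads to compound 3 `CCc1ccc(Nc2nc(SC)nc3ncccc23)cc1`: ethyl in place of chloro on an aromatic carbon. In words, this is ethyl in place of chloro on an aromatic carbon, para to a large group.

For the measured compounds named here, only one measured step bears on this change, and it falls on the same aromatic carbon: a 3.2-fold higher number from compound 1 to compound 2 (0.51 log units; beyond the scatter). That step is modest and covers only fluoro and chloro. Going by the values given here, no measurement yet shows how ethyl behaves, so the guidance is thin. Among the compounds with values here, a small further rise in this assay is expected, in the same direction as the one step seen, though a result within the scatter of compound 2 would be no surprise. The expected change is a 1.4-fold higher number from compound 2 to compound 3 (0.15 log units; within the scatter). For compound 3 the estimated value is 12000 nM, with an expected range of 4500 nM to 32000 nM.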

Compound 3, half-maximal inhibitory concentration: 7150 nM
Beside the measured number, compound 3's estimate is 1.7-fold (0.22 log units) above it; low and high end bracket the measured number.
By their numbers in this assay, from the lowest: compound 1; then compounds 3 and 2 (each within the scatter of the next).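

In this assay, ethyl in place of chloro on an aromatic carbon, para to a large group, gives a 1.2-fold lower number from compound 2 to compound 3 (0.08 log units; within the scatter), so this position does not separate a halogen from a short carbon chain in this pair. Ethyl in place of fluoro on the same carbon gives a 2.7-fold higher number from compound 1 to compound 3 (0.44 log units; beyond the scatter), which leaves compound 1 as the only one of the three whose steps to both others are beyond the scatter, and so the strongest inhibitor among them. Fluoro, not chloro or ethyl, is thus the group that stands apart here, but no supporting measurement accounts for this result.

Still open, from the compounds shown here alone, is whether hydrogen, a methoxy group, a nitrile or an amine on this carbon would fall with fluoro, with chloro and ethyl, or apart from both. For the compounds shown here, a longer chain such as propyl or butyl would show whether the match between compound 2 and compound 3 extends beyond ethyl, and the series so far gives no reading on changes elsewhere on the shared core.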